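Setting one stereocentre in a heptyloxyphenyl amino diol

The source may hold more compounds than are shown below. What is called first, only, known or untested is meant among the compounds shown, and "the series" means these compounds.

Measured so far:
compound 1, `CCCCCCCOc1ccc(CCC(N)(CC)CO)cc1`, 0.044 mg/kg in a functional assay on the whole organism (spleen, spleen) with Rattus norvegicus as the target; on this read-out higher numbers stand for an effect only at larger amounts of compound and lower numbers for an effect already at smaller amounts
compound 2, `CCCCCCCOc1ccc(CCC(N)(CO)CCO)cc1`, 0.055 mg/kg in this assay

Going by the values given here, compound 2 stands at the higher of the two numbers, with compound 1 as its only neighbour, and the step of a 1.3-fold higher number from compound 1 to compound 2 (0.10 log units; within the scatter) is within the scatter, so the two cannot be told apart on these data. That step introduces a hydroxy in place of hydrogen on a saturated chain carbon, three bonds along the chain from an amine nitrogen.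

Compound 3, `CCCCCCCOc1ccc(CC[C@@](N)(CO)CCO)cc1`, is not yet measured. It differs from compound 2 only in this way: the two compounds have the same atoms and bonds; at least one stereo element is drawn with a configuration in one of them and without one in the other: 1 of 1 stereo elements differ; a stereocentre at a saturated chain carbon is drawn without a configuration in compound 2 and S in compound 3. Among the compounds with values here, no measured step involves a change of this kind, so the single step on record from compound 1 to compound 2 does not bear on it. Without such a precedent, the expectation for compound 3 in this assay is simply that it lands close to compound 2, giving an estimated step of a 1.4-fold lower number from compound 2 to compound 3 (0.14 log units; within the scatter). The estimate for compound 3 is 0.04 mg/kg, with a range from 0.015 mg/kg to 0.15 mg/kg.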

Compound 3, dose for 50% inhibition: 0.018 mg/kg
For compound 3 the middle estimate is 2.2-fold (0.35 log units) above the measured one; the measured number falls inside the stated range.
By their numbers in this assay, from the lowest: compound 3; then compounds 1 and 2 (each within the scatter of the next).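

Going by these compounds alone, until now the only change on record, the added hydroxy, left the number in this assay where it was, within the scatter. Drawing the stereocentre as S is the first change that moves it, with a 3.1-fold lower number from compound 2 to compound 3 (0.49 log units; beyond the scatter), which means an effect already at a smaller dose. Compound 1 carries a group of 6 heavy atoms where compound 3 has one of 7, and here the comparison gives a 2.4-fold lower number from compound 1 to compound 3 (0.39 log units; beyond the scatter), so the extra hydroxy comes with a difference beyond the scatter only in the compound whose centre is defined, and that comparison also includes the change in drawn configuration. The only structural ground on record for the gap between compound 2 and compound 3 is this: the fact that one of compounds 2 and 3 is drawn with a defined configuration and the other without, at the place where they differ.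

The compounds shown leave open how the R form of this centre would read, and how the number of compound 2 divides between the two forms its drawing may cover. Also open, from the compounds shown here alone, is whether a longer chain carrying the hydroxy, or a phosphate on that hydroxy, would keep the number of compound 3.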